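This account rests on a few compounds, and the source may have more. Where it says the series, first, only, none or still open, it means among the compounds named here.

Compound 1 `COc1ccc(/C=C/C(=O)c2c(OC)cc(O)c(CC=C(C)C)c2O)cc1OC` gives 13800 nM in a functional assay on HepG2 cells (Homo sapiens) for inhibition, read by MTT assay, with a stated time of 72 h; a higher number here means a weaker inhibitor, a lower number a stronger inhibitor. Compound 2 `COc1cc(O)c(CC=C(C)C)c(O)c1C(=O)/C=C/c1cccc([N+](=O)[O-])c1` gives 16600 nM in this assay, and compound 3 `COc1ccc(/C=C/C(=O)c2c(O)cc(O)cc2OC)cc1OC` gives 18500 nM in this assay. The difference between the cores of compound 1 and compound 2 is not broken down here. Compound 3 arises from compound 1 by one change, (hydrogen in place of 3-methylbut-2-en-1-yl on an aromatic carbon), and this change made a step of a 1.3-fold higher number from compound 1 to compound 3 (0.13 log units; within the scatter). Compound 4 `COc1cc(O)cc(O)c1C(=O)/C=C/c1cccc([N+](=O)[O-])c1`, not yet measured, arises from compound 2 by the same change, (hydrogen in place of 3-methylbut-2-en-1-yl on an aromatic carbon). Because the earlier step of a 1.3-fold higher number from compound 1 to compound 3 (0.13 log units; within the scatter) stayed within the scatter, the step from compound 2 to compound 4 is expected to be about a 1.2-fold higher number from compound 2 to compound 4 (0.08 log units; within the scatter) in this assay. On that basis compound 4 is estimated at 20000 nM in this assay, most likely between 9000 nM and 45000 nM.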

Compound 4, half-maximal inhibitory concentration: 16300 nM
Compound 4: the middle estimate sits 1.2-fold (0.09 log units) above what was measured, within the range that was stated.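

In this assay, hydrogen in place of 3-methylbut-2-en-1-yl on an aromatic carbon gave a 1.0-fold lower number from compound 2 to compound 4 (0.01 log units; within the scatter). Going by these compounds alone, the change therefore behaved alike on the two cores, with both steps small and in agreement: the same change on two cores in this assay, a 1.3-fold higher number (0.13 log units; within the scatter) from compound 1 to compound 3 and a 1.0-fold lower number (0.01 log units; within the scatter) from compound 2 to compound 4, 1.4-fold (0.14 log units) apart, within the scatter of two such steps This shows only that the change made no step beyond the scatter on either core; it does not show that a real effect carries from one core to the other, nor how the change would behave on any further core.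

The compounds shown leave open whether another group on that aromatic carbon, such as a longer chain, an amine or a carboxylic acid, would move the number beyond the scatter. They also leave open whether such a step would carry across both cores.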